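This account rests on a few compounds, and the source may have more. Where it says the series, first, only, none or still open, it means among the compounds named here.

The two measured compounds, each with its result in a functional assay for inhibition, with Rattus norvegicus as the target; on this read-out lower numbers stand for stronger inhibition and higher numbers for weaker inhibition:
compound 1 `CCC(C)(C)/N=c1\c(O)c(O)\c1=N/Cc1c(C)cccc1Cl` gives 4400 nM
compound 2 `CCC(C)(C)/N=c1\c(O)c(O)\c1=N/Cc1c(C)cccc1C` gives 830 nM

Compound 1 stands as the higher of the two numbers, which here means the weaker inhibition. For the measured compounds named here, its only neighbour is compound 2, and the step of a 5.3-fold lower number from compound 1 to compound 2 (0.72 log units; beyond the scatter) is modest but beyond the scatter; it comes from a single change on an aromatic carbon, where methyl takes the place of chloro.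

Compound 3 `CCC(C)(C)/N=c1\c(O)c(O)\c1=N/Cc1c(Cl)cccc1Cl` has not yet been measured in this assay. It differs from compound 1 in one place:
chloro in place of methyl on an aromatic carbon
Going by the values given here, only one measured step bears on this change, the one from compound 1 to compound 2, a 5.3-fold lower number from compound 1 to compound 2 (0.72 log units; beyond the scatter), in which a chloro giving way to a methyl lowered the number. Compound 3 goes the other way: a methyl leaves and a chloro enters, so the shared core now carries two chloro groups. Read in reverse, that step suggests a higher number, so weaker inhibition is expected for compound 3, by roughly a 2.3-fold higher number from compound 1 to compound 3 (0.36 log units; beyond the scatter). Because compound 1 already sits at 4400 nM, the value expected for compound 3 is 10000 nM, in a range from 3000 nM to 30000 nM. This rests on one step only, and on a different group than the one that moved there, so the range is kept wide.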

Compound 3, half-maximal inhibitory concentration: 280 nM
Estimate against measurement, compound 3: 36-fold (1.55 log units) above, and the stated range ends above it.
By their numbers in this assay, from the lowest: compound 3; then compound 2; then compound 1.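

In this assay, putting chloro in place of methyl on this aromatic carbon gives a 16-fold lower number from compound 1 to compound 3 (1.20 log units; beyond the scatter), a large step in the same direction as the modest one for the opposite exchange, a 5.3-fold lower number from compound 1 to compound 2 (0.72 log units; beyond the scatter). The two changes run opposite ways in terms of groups, yet both lower the number, so methyl and chloro have no fixed order at this kind of place: which one gives the lower number depends on what the rest of the ring carries. Among these three compounds, the one with one methyl and one chloro, compound 1, has the highest number, and replacing either group so that the two match lowers it, while nothing measured on these compounds explains this behaviour.

As far as these compounds go, what a fluoro, a methoxy or an amine would do on this carbon remains open, since only methyl and chloro appear there. From the compounds shown here alone, it is also open whether the same exchanges would lower the number when another part of the shared core carries a different group, such as a longer chain.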